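The compounds below may be only part of what the source reports. "The series", "measured", "known", "first", "only" and "open" are said of these compounds alone.

Of the compounds shown here, three have been measured in a functional assay on HT-1080 cells (Homo sapiens) for antiproliferative activity, read by sulforhodamine B assay, with a stated time of 48 h (on this read-out higher numbers stand for weaker inhibition and lower numbers for stronger inhibition), all sharing one core that carries an acyl group on an amide-type nitrogen. Compound 1 `CC(=O)Nc1ccc(S(=O)(=O)Oc2ccccc2I)cc1` gives 17000 nM. Compound 2 `CCCC(=O)Nc1ccc(S(=O)(=O)Oc2ccccc2I)cc1` gives 2000 nM. Compound 3 `O=C(CCl)Nc1ccc(S(=O)(=O)Oc2ccccc2I)cc1` gives 600 nM and thus stands lowest of the three, that is, strongest in this assay. The steps leading to it are a 28-fold lower number from compound 1 to compound 3 (1.45 log units; beyond the scatter) and a 3.3-fold lower number from compound 2 to compound 3 (0.52 log units; beyond the scatter), while an 8.5-fold lower number from compound 1 to compound 2 (0.93 log units; beyond the scatter) describes the shift between the other two.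

Compound 4 `CCCCCNC(=O)Nc1ccc(S(=O)(=O)Oc2ccccc2I)cc1` has not been measured yet. It differs from compound 3 by pentylamino in place of chloromethyl on a carbonyl carbon, so the acyl group becomes a urea-type group carrying a five-carbon chain. Among the measured compounds shown here, no measured step involves this exact exchange, but two bear on leaving the chloro-bearing group: a 3.3-fold lower number from compound 2 to compound 3 (0.52 log units; beyond the scatter) and a 28-fold lower number from compound 1 to compound 3 (1.45 log units; beyond the scatter) both show that compound 3 has the lowest number and that replacing the chloro by something else raised the number, modestly in one case and by a large margin in the other. Compound 4 is therefore expected to give a higher number than compound 3, with the step estimated as a 5.0-fold higher number from compound 3 to compound 4 (0.70 log units; beyond the scatter). The estimate for compound 4 in this assay is 3000 nM, expected to lie between 800 nM and 12000 nM.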

Compound 4, half-maximal inhibitory concentration: 6900 nM
Estimate against measurement, compound 4: 2.3-fold (0.36 log units) below; the measured number falls inside the stated range.
By their numbers in this assay, from the lowest: compound 3; then compound 2; then compound 4; then compound 1.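

In this assay, pentylamino on the carbonyl carbon places compound 4 inside the series rather than at either end: there is a 12-fold higher number from compound 3 to compound 4 (1.06 log units; beyond the scatter) against the chloromethyl group, a 3.5-fold higher number from compound 2 to compound 4 (0.54 log units; beyond the scatter) against the propyl group, and still a 2.5-fold lower number from compound 1 to compound 4 (0.39 log units; beyond the scatter) against the methyl group. The step from methyl to propyl had hinted that a longer chain on this carbonyl carbon goes with a lower number, but compound 4 goes against that hint, since its pentylamino group is the longest chain shown and its number is higher than that of compound 2. No measurement of any property in this set accounts for these shifts.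

Compound 4 changes two things at once, the chain length and the nitrogen joined to the carbonyl carbon, so the compounds shown cannot tell which of them goes with the higher number. A pentyl chain joined directly to the carbonyl carbon, or a shorter methylamino group in the same place, would pull the two apart, and a bromomethyl group would test whether the low number of compound 3 is tied to chlorine itself.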